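The source may hold more compounds than are shown below. What is called first, only, known or untested is meant among the compounds shown, and "the series" means these compounds.

Compound 1 `O=c1cc(/C=C/c2ccc(OC(F)(F)F)cc2)oc2ccccc12` gives 28900 nM. Compound 2 `COc1cc(OC)c2c(=O)cc(/C=C/c3ccc(C(F)(F)F)cc3)oc2c1` reaches only a limit of the assay, > 40000 nM. Compound 3 `COc1cc(OC)c2c(=O)cc(/C=C/c3ccc(F)cc3)oc2c1` also reaches only a limit of the assay, > 40000 nM.

In a functional assay on PC-3 cells (Homo sapiens) for antiproliferative activity, read by MTT assay, with a stated time of 12 h (a higher number here means a weaker inhibitor, a lower number a stronger inhibitor), compound 1 is the only one of the three with a number. Compound 3 stands at a limit, so its true value is not known. Going by the values given here, the step that the two limits leave unreadable from compound 2 to compound 3 cannot be read because the limit of > 40000 nM in this assay, at which 2 of the 3 values shown sit, holds both of its ends, and so no measured step gives a readable size for any change on this core.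

Compound 4 `COc1cc(OC)c2c(=O)cc(/C=C/c3ccccc3)oc2c1` differs from compound 3 by hydrogen in place of fluoro on an aromatic carbon. Among the compounds with values here, no measured step bears on this change, and compound 3 itself offers only a limit, so there is no basis to expect a step in this assay in either direction beyond the scatter. Compound 4 is therefore expected to sit near the same limit, with the estimated step that the limit leaves unreadable from compound 3 to compound 4. The estimate for compound 4 in this assay is 45000 nM, between 20000 nM and 100000 nM.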

Compound 4, half-maximal inhibitory concentration: > 40000 nM
Compound 4 was reported as a limit; the forecaster's own chance of this, stated with the estimate: 65%; the middle value is on the limit's open side.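

Compound 4 also stands at a limit, so the steps to it from compound 3 and compound 2 cannot be read in this assay, because both ends of each step sit at the same limit: the limit of > 40000 nM in this assay, at which 3 of the 4 values shown sit.

On these data alone, whether hydrogen, fluoro and trifluoromethyl differ at all on the shared core remains open.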